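From methoxy to benzyloxycarbonyl on a shared core

The source may report more compounds than this note shows. Statements on the series, on what has been measured and on what is new or still open speak of the compounds shown alone.

Compound 1 `Clc1ccc2[nH]c(-c3cn(-c4ccccc4)nc3-c3ccccc3)nc2c1`: 1960 nM
Compound 2 `COc1ccc2[nH]c(-c3cn(-c4ccccc4)nc3-c3ccccc3)nc2c1`: 1590 nM

Going by the values given here, in a functional assay on MCF7 cells (Homo sapiens) for antiproliferative activity, read by MTT assay, with a stated time of 48 h (a lower number here means a stronger inhibitor, a higher number a weaker inhibitor), the only measured step is a 1.2-fold lower number from compound 1 to compound 2 (0.09 log units; within the scatter), so compound 2 stands level with compound 1. Compound 3 `O=C(OCc1ccccc1)c1ccc2[nH]c(-c3cn(-c4ccccc4)nc3-c3ccccc3)nc2c1` carries benzyloxycarbonyl in place of methoxy on an aromatic carbon. Among the compounds with values here, no measured compound carries this group, and the chloro-to-methoxy step of a 1.2-fold lower number from compound 1 to compound 2 (0.09 log units; within the scatter) is the only guide. That step gives no direction, so no shift beyond the scatter is expected, though with much uncertainty. The expected change is a 1.3-fold higher number from compound 2 to compound 3 (0.10 log units; within the scatter). Compound 3 is estimated at 2000 nM, within an expected range of 500 nM to 8000 nM.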

Compound 3, half-maximal inhibitory concentration: 12600 nM
Beside the measured number, compound 3's estimate is 6.3-fold (0.80 log units) below it; the measured number lies above the stated range.
By their numbers in this assay, from the lowest: compounds 2 and 1 (each within the scatter of the next); then compound 3.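

In this assay, this position turns out to respond to what sits on it: chloro and methoxy stood within the scatter of each other, but benzyloxycarbonyl gives a 7.9-fold higher number from compound 2 to compound 3 (0.90 log units; beyond the scatter) and a 6.4-fold higher number from compound 1 to compound 3 (0.81 log units; beyond the scatter). The change is therefore a real loss of activity against both earlier compounds. No measurement at hand explains this loss.

Benzyloxycarbonyl adds a carbonyl and a six-membered aromatic ring together, so the compounds shown cannot separate their contributions. A carboxylic acid or a benzyloxy group at this place would help to tell them apart.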